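Sulfonate Ester Exchange Starting from an Assay Limit

The source may report more compounds than this note shows. Statements on the series, on what has been measured and on what is new or still open speak of the compounds shown alone.

The account concerns compound 1 `CS(=O)(=O)Oc1c(C(=O)NCc2ccc(F)cc2)nc(Br)c2cccnc12` and its close relative compound 4 `Cc1ccc(S(=O)(=O)Oc2c(C(=O)NCc3ccc(F)cc3)nc(Br)c3cccnc23)cc1`, examined in a functional assay on MDA-MB-435 cells (Homo sapiens) for cytotoxicity, read by MTT assay, with a stated time of 72 h; on this read-out lower numbers stand for stronger inhibition and higher numbers for weaker inhibition. In this assay compound 1 gives only a limit, > 20000 nM, and no number. Two further compounds stand in the same place. Compound 2 `COC(=O)c1nc(Br)c2cccnc2c1N[C@H]1CC[C@H](N)CC1` likewise reaches only the limit > 20000 nM in this assay. Compound 3 `C[C@H](CO)Nc1nc(C(=O)NCc2ccc(F)cc2)c(O)c2ncccc12` also stops at the limit, > 20000 nM, in this assay. Among the compounds with values here, every value so far therefore rests at the limit of > 20000 nM in this assay, at which 3 of the 3 values shown sit, and nothing in the measurements separates one compound from another.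

Compound 4 differs from compound 1 in a single respect: 4-methylphenyl in place of methyl on a sulfonyl sulfur. Within the data shown here, the enlarged sulfonate ester is the only change; the amide, the bromine and the shared core of compound 1 remain as they are.

Among the measured compounds shown here, no pair of measured compounds differing in one place exists, so this step has no measured counterpart. With all three values resting at the same limit, the estimated step that the limit leaves unreadable from compound 1 to compound 4 amounts to none beyond the scatter. Compound 4 is accordingly expected to give about 25000 nM in this assay, within a range from 8000 nM to 80000 nM, and most likely to be reported again only as a limit.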

Compound 4, half-maximal inhibitory concentration: > 20000 nM
Compound 4 gave a limit, no number (the forecaster's own chance of this, stated with the estimate: 80%); the middle value lies beyond the limit too.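

In this assay, within the data shown here, compound 1 and compound 4 each rest at a limit and give no number, and no step between them can be read. All values shown stand at the same place: the limit of > 20000 nM in this assay, at which 4 of the 4 values shown sit.

The compounds shown leave open whether exchanging methyl for 4-methylphenyl on the sulfonyl sulfur changes inhibition in this assay.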